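The source may hold more compounds than are shown below. What is called first, only, known or untested is meant among the compounds shown, and "the series" means these compounds.

Working notes on the series. In a functional assay on U-87MG ATCC cells for antiproliferative activity against U-87 MG (Homo sapiens), read by spectrophotometry, with a stated time of 2 days (on this read-out higher numbers stand for weaker inhibition of growth and lower numbers for stronger inhibition of growth), compound 1 `Cc1cc(F)ccc1Nc1ncc(C(F)(F)F)c(N2Cc3cccc(N(C)S(C)(=O)=O)c3C2)n1` gives > 30000 nM, which is a limit of the assay and not a number. That places compound 1 at the limit of > 30000 nM in this assay, at which 1 of the 2 values shown sits. Going by the values given here, compound 2 `CN(c1cccc2c1CN(c1nc(Nc3cccc(Oc4ccccc4)c3)ncc1C(F)(F)F)C2)S(C)(=O)=O` gives 19500 nM in this assay, the only true number so far, and it also marks weak inhibition of growth.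

The next compound to read is compound 3 `CN(c1cccc2c1CN(c1nc(Nc3ccc(Cl)c(C(F)(F)F)c3)ncc1C(F)(F)F)C2)S(C)(=O)=O`, which keeps the core of compound 1 and changes one group: 4-chloro-3-(trifluoromethyl)phenyl in place of 4-fluoro-2-methylphenyl on a nitrogen on an aromatic ring. In words, 4-chloro-3-(trifluoromethyl)phenyl stands in place of 4-fluoro-2-methylphenyl on a nitrogen on an aromatic ring.

Among the compounds with values here, no measured step covers this change, so the expectation is loose. Within the data shown here, compound 2 at 19500 nM is the only guide, and it suggests that a number, when one appears, stays in the weak region. A modest shift towards stronger inhibition of growth is expected, and the estimated step is an at least 2.7-fold lower number from compound 1 to compound 3 (0.43 log units; beyond the scatter). A second reading at the limit of this assay remains a real possibility. For compound 3 the expected value is 11000 nM, with an estimated range from 3000 nM to 30000 nM.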

Compound 3, concentration for 50% growth inhibition: > 30000 nM
Compound 3 was reported as a limit; the forecaster's own chance of this, stated with the estimate: 30%; middle value at least 2.7-fold (0.43 log units) away from the limit.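

In this assay compound 3 gives > 30000 nM, which is a limit of the assay and not a number. Going by these compounds alone, with compound 1 also reported as a limit, no step from compound 1 to compound 3 can be read: the limit of > 30000 nM in this assay, at which 2 of the 3 values shown sit. The compounds shown leave open whether 4-chloro-3-(trifluoromethyl)phenyl and 4-fluoro-2-methylphenyl differ at all in this assay.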